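Series notes: methoxy to hydrogen on the chain carbon

This account rests on a few compounds, and the source may have more. Where it says the series, first, only, none or still open, it means among the compounds named here.

Measured compounds:
compound 1 `Cc1nc(C)n2c(=O)n(C)ncc12`; in a functional assay for inhibition, with Homo sapiens as the target (on this read-out higher numbers stand for weaker inhibition and lower numbers for stronger inhibition), compound 1 gives > 48000 nM, which is a limit of the assay and not a number.
compound 2 `C=CCn1ncc2cnc(COC)n2c1=O`; in this assay compound 2 gives > 48000 nM, again a limit.
compound 3 `CCn1ncc2cncn2c1=S`; in this assay compound 3 gives > 48000 nM, again a limit.

Compound 2 therefore stands nowhere that can be placed against the other two: its value is a limit, and the two further values shown are limits as well, so no order among the three can be read off. Going by the values given here, the only evidence on the set is the limit of > 48000 nM in this assay, at which 3 of the 3 values shown sit.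

The step under consideration leads to compound 4 `C=CCn1ncc2cnc(C)n2c1=O`, which differs from compound 2 by hydrogen in place of methoxy on a saturated chain carbon bound to an aromatic carbon, or, cut one bond further out, methoxymethyl to methyl. Among the compounds with values here, no step between measured compounds that differ in one place exists, so nothing measured speaks for a shift in either direction. Given that compound 2 sits at the limit (the limit of > 48000 nM in this assay, at which 3 of the 3 values shown sit), the expected step from compound 2 to compound 4 is none beyond the scatter, a step that the limit leaves unreadable from compound 2 to compound 4. For compound 4 the estimate in this assay is 70000 nM, expected between 20000 nM and 250000 nM, most likely reported again only as a limit.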

Compound 4, half-maximal inhibitory concentration: > 48000 nM
Compound 4: a limit, no number; the forecaster's own chance of this, stated with the estimate: 85%; the middle value lies beyond the limit too.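

In this assay compound 4 gives > 48000 nM as a limit, not a number. Compound 2 stands at a limit as well, so no step can be read between compound 2 and compound 4. The compounds shown leave open whether hydrogen in place of methoxy shifts inhibition at all, and how any of them rank: the limit of > 48000 nM in this assay, at which 4 of the 4 values shown sit.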